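Cyclopropyl for methyl on the sulfonyl of compound 3

The source may report more compounds than this note shows. Statements on the series, on what has been measured and on what is new or still open speak of the compounds shown alone.

In a functional assay on NCI-H1975 cells (Homo sapiens) for inhibition, read by sulforhodamine B assay, tested at 10 uM (a lower number here means less inhibition, a higher number more inhibition at the concentration tested (going by the name of the read-out)), compound 3 `CN1CCN(c2ccc(C3=NN(S(C)(=O)=O)C(c4ccc(N(C)C)cc4)C3)cc2)CC1` gives -1.3%, the second highest of the three numbers, though within the scatter of both others: compound 2 `Cc1ccc(C(=O)N2N=C(c3ccc(N4CCN(C)CC4)cc3)CC2c2ccc(N(C)C)cc2)cc1` gives -0.4% and compound 1 `COC(=O)CC(=O)N1N=C(c2ccc(N3CCN(C)CC3)cc2)CC1c1ccc(N(C)C)cc1` gives -2.2%. Compound 4 `CN1CCN(c2ccc(C3=NN(S(=O)(=O)C4CC4)C(c4ccc(N(C)C)cc4)C3)cc2)CC1` differs from compound 3 by cyclopropyl in place of methyl on a sulfonyl sulfur. Within the data shown here, the measured steps that touch this place are a number 0.9 percentage points higher from compound 1 to compound 3 (within the scatter) and a number 0.9 percentage points lower from compound 2 to compound 3 (within the scatter), both exchanges of the group on the ring nitrogen and both within the scatter; no measured step alters the group on the sulfonyl sulfur itself. All three measured compounds lie within the scatter of one another in this assay, so no step beyond the scatter is expected, and a number 1.3 percentage points higher from compound 3 to compound 4 (within the scatter) is the estimated step. Compound 4 is therefore expected to give 0%, within a range from -10% to 10%.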

Compound 4, a percentage reported as inhibition, at one concentration (the size of the read-out at that concentration, not a potency): 0.2%
Compound 4: middle estimate off by 0.2 percentage points, on the low side; measured number inside the range.
By their numbers in this assay, from the lowest: compounds 1, 3, 2 and 4 (each within the scatter of the next).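

In this assay, among these compounds, the group on the sulfonyl sulfur changes for the first time, and exchanging methyl for cyclopropyl gives a number 1.5 percentage points higher from compound 3 to compound 4 (within the scatter). Cyclopropylsulfonyl in place of the acyl groups on the ring nitrogen gives a number 0.6 percentage points higher from compound 2 to compound 4 (within the scatter) and a number 2.4 percentage points higher from compound 1 to compound 4 (within the scatter), so the added three-membered ring separates compound 4 from none of the others. No evidence is available that bears on this result.

Going by these compounds, whether a phenyl ring, an amine or a longer chain on the sulfonyl sulfur would give a step beyond the scatter remains open.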